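Amino for Chloro on a Shared Fused Core

The source may report more compounds than this note shows. Statements on the series, on what has been measured and on what is new or still open speak of the compounds shown alone.

Of the compounds shown here, three have so far been measured in a functional assay on OVCAR-3 cells (Homo sapiens) for cytotoxicity, read by sulforhodamine B assay, with a stated time of 48 h; a higher number here means a weaker inhibitor of growth, a lower number a stronger inhibitor of growth. Compound 1 `Nc1nc(Cl)c2ncn(Cc3ccc(CCl)cc3)c2n1` gives 2140 nM. Compound 2 `ClCc1cccc(Cn2cnc3c(Cl)nc(Cl)nc32)c1` gives 1580 nM in this assay, and compound 3 `ClCc1ccc(Cn2cnc3c(Cl)nc(Cl)nc32)cc1` gives 2000 nM. Compound 3 and compound 1 differ in a single place: amino in place of chloro on an aromatic carbon. The measured effect of this change was a 1.1-fold higher number from compound 3 to compound 1 (0.03 log units; within the scatter). Compound 2 and compound 3 are made of the same atoms joined differently; the difference between the two cores is not broken down here. Their values in this assay lie within the scatter of each other, and the same holds for compound 2 against compound 1, so no order among the three can be stated.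

Compound 4 `Nc1nc(Cl)c2ncn(Cc3cccc(CCl)c3)c2n1` has not yet been measured in this assay. It stands to compound 2 exactly as compound 1 stands to compound 3: amino in place of chloro on an aromatic carbon. The surroundings of the altered carbon are described in the same words in both cases, so this is the same change, seen twice among the compounds shown. Because the first instance produced a 1.1-fold higher number from compound 3 to compound 1 (0.03 log units; within the scatter), the expected outcome is a number close to that of compound 2, with the new figure possibly a little higher. The estimate therefore means a step of a 1.1-fold higher number from compound 2 to compound 4 (0.04 log units; within the scatter). Compound 4 is expected to give 1750 nM in this assay, with the likely span reaching from 900 nM up to 3500 nM.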

Compound 4, concentration for 50% growth inhibition: 720 nM
The estimate for compound 4 lay 2.4-fold (0.39 log units) above the measured number, outside the stated range (below it).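

In this assay, amino in place of chloro on an aromatic carbon gave a 2.2-fold lower number from compound 2 to compound 4 (0.34 log units; beyond the scatter), a modest step, and the only one of the two instances of this change that stands clear of the scatter. Set beside the earlier instance, the two steps cannot be told apart, even though only one of them is beyond the scatter taken alone: the same change on two cores in this assay, a 1.1-fold higher number (0.03 log units; within the scatter) from compound 3 to compound 1 and a 2.2-fold lower number (0.34 log units; beyond the scatter) from compound 2 to compound 4, 2.3-fold (0.37 log units) apart, within the scatter of two such steps. This shows that the two cores give no measurable evidence of responding differently to the change, but it does not show that the change carries over with a fixed size, nor that the core has no influence, and with only two instances neither a lasting gain from amino nor its true size can be stated.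

The compounds shown hold only chloro or amino at this carbon, so it remains open how a methylamino or a methoxy group there would read in this assay. Every compound shown also carries the chloromethyl group, which leaves open what a hydroxymethyl or a plain methyl group in its place would do to growth inhibition on either core.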